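The source may hold more compounds than are shown below. What is called first, only, known or untested is meant among the compounds shown, and "the series" means these compounds.

Three compounds built on a shared core were tested in a functional assay on MNK45 cells (Homo sapiens) for inhibition, read by MTT assay, with a stated time of 48 h; a lower number here means a stronger inhibitor, a higher number a weaker inhibitor. Compound 1 `O=C(NC(=S)Nc1ccc(Cl)c(-c2nc3ccccc3[nH]2)c1)c1ccc(OCc2ccc(C(F)(F)F)cc2)cc1` gives 7830 nM in this assay. Compound 2 `Cc1ccc(NC(=O)NC(=O)c2ccc(OCc3cccc(Cl)c3)cc2)cc1-c1nc2ccccc2[nH]1` gives 28000 nM, and compound 3 `Cc1ccc(NC(=O)NC(=O)c2ccc(OCc3cccc(Cl)c3Cl)cc2)cc1-c1nc2ccccc2[nH]1` gives 87000 nM. Compound 3 thus stands at the highest of the three numbers: the step of a 3.1-fold higher number from compound 2 to compound 3 (0.49 log units; beyond the scatter) separates it from its nearest neighbour, while the values of compound 1 and compound 3 lie still further apart, compound 1 being the lower of the two. The next compound, compound 4 `Cc1ccc(NC(=O)NC(=O)c2ccc(OCc3ccc(Cl)c(Cl)c3)cc2)cc1-c1nc2ccccc2[nH]1`, differs from compound 3 in a single place: 3,4-dichlorophenyl in place of 2,3-dichlorophenyl on a saturated chain carbon bound to an oxygen on an aromatic ring. For the measured compounds named here, no measured step bears directly on this change. Going by the values given here, the only step recorded, a 3.1-fold higher number from compound 2 to compound 3 (0.49 log units; beyond the scatter), concerns the addition of a chloro group to a ring that already carried one, not a rearrangement of two chloro groups that are both kept, and it was of modest size. Among the compounds with values here, with the same atoms joined differently and no comparable step to lean on, the step of a 1.7-fold lower number from compound 3 to compound 4 (0.24 log units; within the scatter) is expected to be modest at most, in either direction, and possibly within the scatter. Compound 4 is therefore expected to give about 50000 nM in this assay, within a range from 15000 nM to 150000 nM.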

Compound 4, half-maximal inhibitory concentration: 5820 nM
Estimate against measurement, compound 4: 8.6-fold (0.93 log units) above, and the stated range ends above it.
By their numbers in this assay, from the lowest: compounds 4 and 1 (each within the scatter of the next); then compound 2; then compound 3.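

In this assay, moving the two chloro groups while keeping every atom gives a 15-fold lower number from compound 3 to compound 4 (1.17 log units; beyond the scatter), which shows that on a saturated chain carbon bound to an oxygen on an aromatic ring, the arrangement of the chloro groups matters and not only their number. The same change, chloro in place of hydrogen on an aromatic carbon, had given a 3.1-fold higher number from compound 2 to compound 3 (0.49 log units; beyond the scatter), but it now gives a 4.8-fold lower number from compound 2 to compound 4 (0.68 log units; beyond the scatter), so the direction of this change depends on which ring carbon takes the added chloro. Nothing available here explains why 3,4-dichlorophenyl and 2,3-dichlorophenyl differ so widely.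

The compounds shown do not tell whether a 4-chlorophenyl group in this place, with its single chloro, would give a number closer to that of compound 2 or to that of compound 4. They also leave open whether the gain seen with 3,4-dichlorophenyl is specific to chloro, as a 3,4-difluorophenyl or 3,4-dimethoxyphenyl group in the same place would show, and how the isomeric 3,5-dichlorophenyl group would compare.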